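The compounds below may be only part of what the source reports. "The series", "measured", "known", "first", "only" and "open" are said of these compounds alone.

Of the compounds shown here, three have so far been measured in a functional assay on NCI-H226 cells (Homo sapiens) for cytotoxicity, read by sulforhodamine B assay, with a stated time of 48 h; on this read-out higher numbers stand for weaker inhibition of growth and lower numbers for stronger inhibition of growth. Compound 1 `Nc1nc(Cl)c2ncn(Cc3ccccc3CCl)c2n1` gives 10000 nM in this assay. Compound 3 `ClCc1ccccc1Cn1cnc2nc(Cl)nc(Cl)c21` gives 6760 nM, a number within the scatter of that of compound 1. Compound 2 `Nc1nc(Cl)c2ncn(Cc3ccc(CCl)cc3)c2n1` gives 37200 nM, a higher number than compound 1 by a margin beyond the scatter. Compound 1 therefore stands second highest of the three numbers. Compound 4 `ClCc1ccccc1Cn1cnc2c(Cl)ncnc21` has not yet been measured; it differs from compound 1 by hydrogen in place of amino on an aromatic carbon of the shared core. For the measured compounds named here, no measured pair shows this change, so the step is expected to be a 1.5-fold higher number from compound 1 to compound 4 (0.18 log units; within the scatter), toward a somewhat higher number but not clearly beyond the scatter. The estimate for compound 4 is 15000 nM, with a range from 5000 nM to 45000 nM.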

Compound 4, concentration for total growth inhibition: 12600 nM
Compound 4: the middle estimate sits 1.2-fold (0.08 log units) above what was measured; low and high end bracket the measured number.
By their numbers in this assay, from the lowest: compounds 3, 1 and 4 (each within the scatter of the next); then compound 2.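

In this assay, hydrogen in place of amino on the aromatic carbon between two ring nitrogen atoms gives a 1.3-fold higher number from compound 1 to compound 4 (0.10 log units; within the scatter) and thus no step beyond the scatter. At this position, therefore, compound 4 without the amino group cannot be told apart from compound 1 by this read-out. No available evidence bears on this result.

As far as these compounds go, whether a methoxy or dimethylamino group at this position would also stay within the scatter remains open. So does whether the amino group matters when the chloromethyl group sits as in compound 2.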